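The source may hold more compounds than are shown below. What is called first, only, known or untested is meant among the compounds shown, and "the series" means these compounds.

Measured compounds:
- compound 1, `COc1cc(NC(=O)c2ccc(C#N)cc2)ccc1NS(=O)(=O)C(F)(F)F`: in an ADME assay on RAW264.7 cells (Mus musculus) for cytotoxicity, read by MTT assay, with a stated time of 48 h (a lower number here means a stronger inhibitor, a higher number a weaker inhibitor), compound 1 reaches only the assay limit, > 250000 nM.
- compound 2, `CCS(=O)(=O)Nc1ccc(NC(=O)c2ccc(C#N)cc2)cc1Cl`: in this assay compound 2 gives 226000 nM.

Compound 2 stands as the only numerical value in this assay; the other result shown is a limit, (the limit of > 250000 nM in this assay, at which 1 of the 2 values shown sits). Compound 3, `N#Cc1ccc(C(=O)Nc2ccc(NS(=O)(=O)C(F)(F)F)c(Cl)c2)cc1`, is not yet measured. It differs from compound 2 by trifluoromethyl in place of ethyl on a sulfonyl sulfur. Among the measured compounds shown here, no measured pair differs in only this place, so no measured step guides the expectation; the only other trifluoromethylsulfonyl compound, compound 1, carries a different group on the shared core and sits at the limit. Both measured results lie in the same weak region, and the step from compound 2 to compound 3 is expected to stay within the scatter, a 1.1-fold higher number from compound 2 to compound 3 (0.03 log units; within the scatter). For compound 3 in this assay the estimate is 240000 nM, range 120000 nM to 500000 nM, with a real chance that only a limit is reported.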

Compound 3, half-maximal inhibitory concentration: > 250000 nM
Compound 3: no number, only a limit; the forecaster's own chance of this, stated with the estimate: 55%; at least 1.0-fold (0.01 log units) between middle value and limit.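

In this assay, among the compounds shown here, trifluoromethyl in place of ethyl on a sulfonyl sulfur gives an at least 1.1-fold higher number from compound 2 to compound 3 (0.04 log units; that floor lies within the scatter), the first measured pair that differs only at this position. This floor gives no upper bound, so a larger step remains possible, while the change yields no number in a stronger region. The step with chloro in place of methoxy on an aromatic carbon cannot be read, and compound 1 and compound 3, the two trifluoromethyl compounds, both end at a limit rather than a number: the limit of > 250000 nM in this assay, at which 2 of the 3 values shown sit.

Going by these compounds, how far the results of compound 1 and compound 3 lie past that limit remains open. Also open, on these data alone, is what a longer chain, such as propyl, or an amine on the sulfonyl sulfur would give in this assay.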